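Furan for Thiophene on a Fused Core

The compounds below may be only part of what the source reports. "The series", "measured", "known", "first", "only" and "open" are said of these compounds alone.

Within the data shown here, compound 2 `COc1cc(-c2nnc3n2NC(c2cccs2)C(C(=O)c2ccc(C)cc2)S3)cc(OC)c1OC` is the only compound of this set with a numerical result in a functional assay on PC-3 cells (Homo sapiens) for cytotoxicity, read by MTT assay, with a stated time of 48 h (a higher number here means a weaker inhibitor, a lower number a stronger inhibitor), where compound 2 gives 5090 nM. Compound 1 `COc1cc(-c2nnc3n2NC(c2ccco2)C(C(=O)c2ccccc2F)S3)cc(OC)c1OC`, which carries a furan-2-yl group together with a (2-fluorophenyl)carbonyl group on the shared core, gives in this assay only a limit, > 100000 nM. That reading is the limit of > 100000 nM in this assay, at which 1 of the 2 values shown sits. Compound 3 `COc1cc(-c2nnc3n2NC(c2ccco2)C(C(=O)c2ccc(C)cc2)S3)cc(OC)c1OC` differs from compound 2 by furan-2-yl in place of thiophen-2-yl on a saturated ring carbon. Among the measured compounds shown here, no measured pair isolates this single change, and compound 1 also differs in its carbonyl group, so the two measured values do not settle the matter. Compound 3 is expected to give 8000 nM in this assay, with an estimated range from 2500 nM to 40000 nM. The step of a 1.6-fold higher number from compound 2 to compound 3 (0.20 log units; within the scatter) is expected to be a modest weakening, close to the usual scatter.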

Compound 3, half-maximal inhibitory concentration: 7500 nM
For compound 3 the middle estimate is 1.1-fold (0.03 log units) above the measured one, and the stated range covers the measured number.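

With the (4-methylphenyl)carbonyl group held fixed, furan-2-yl in place of thiophen-2-yl gives a 1.5-fold higher number from compound 2 to compound 3 (0.17 log units; within the scatter), so this assay does not separate these two rings at this saturated ring carbon. With furan-2-yl held fixed, 4-methylphenyl in place of 2-fluorophenyl on the carbonyl carbon gives an at least 13-fold lower number from compound 1 to compound 3 (1.12 log units; beyond the scatter), so the large gap between compound 1 and compound 3 goes with the group on the carbonyl and not with the furan-2-yl group. Compound 1 stands at a limit and not at a number, so the true size of that step stays unknown: the limit of > 100000 nM in this assay, at which 1 of the 3 values shown sits.

As far as these compounds go, whether a phenyl ring or a cyclohexyl group on this ring carbon would give a similar reading remains open. Also open, from the compounds shown here alone, is whether a 4-fluorophenyl group on the carbonyl carbon would follow compound 1 or compound 3.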